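Notes on the step from compound 2 to compound 3

A few compounds are considered here, and "the series" means these few. Any claim that something is new, unique, unknown or untested is made for them only; others in the source may bear on it.

Values in a functional assay on PC-3 cells (Homo sapiens) for cytotoxicity (on this read-out lower numbers stand for an effect already at smaller amounts and higher numbers for an effect only at larger amounts of compound), for the two measured compounds:
- Compound 1 `COC1=C(C)C(=O)/C(=C(O)/C=C/c2ccc(O)cc2)C(=O)C1(C)C` gives > 20 ug/mL (a limit of the assay)
- Compound 2 `CCc1ccc(/C=C/C(O)=C2/C(=O)C(C)=C(OC)C(C)(C)C2=O)cc1` gives 15.1 ug/mL (a number)

Among the measured compounds shown here, compound 2 gives 15.1 ug/mL as the only number so far. For compound 1 the reading is a limit only (the limit of > 20 ug/mL in this assay, at which 1 of the 2 values shown sits). Compound 3 `COC1=C(C)C(=O)/C(=C(O)/C=C/c2c(C)cccc2C)C(=O)C1(C)C` comes next, with 2,6-dimethylphenyl in place of 4-ethylphenyl on a double-bonded chain carbon bound to a double-bonded chain carbon as its difference from compound 2, namely 2,6-dimethylphenyl in place of 4-ethylphenyl on a double-bonded chain carbon bound to a double-bonded chain carbon. Compound 2 and compound 3 have the same atoms, joined differently. For the measured compounds named here, the one measured step shows an at least 1.3-fold lower number from compound 1 to compound 2 (0.12 log units; that floor lies within the scatter) with ethyl in place of hydroxy on an aromatic carbon, a different change that sets no size for the new one. No step beyond the scatter is therefore expected in this assay in either direction. The expected step is a 1.0-fold lower number from compound 2 to compound 3 (0.00 log units; within the scatter) as estimated here. For compound 3 the estimated value is 15 ug/mL with an expected range from 7 ug/mL to 30 ug/mL in this estimate.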

Compound 3, concentration for half-maximal effect: 17.1 ug/mL
Compound 3: middle estimate off by 1.1-fold (0.06 log units), on the low side, and the stated range covers the measured number.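

In this assay, the same eight carbons arranged as 4-ethylphenyl or as 2,6-dimethylphenyl on a double-bonded chain carbon bound to a double-bonded chain carbon give a 1.1-fold higher number from compound 2 to compound 3 (0.05 log units; within the scatter), so this rearrangement of the aromatic group leaves no readable change in this assay. The reading for compound 1 is a limit of the assay and not a number: the limit of > 20 ug/mL in this assay, at which 1 of the 3 values shown sits.
The other new step, an at least 1.1-fold lower number from compound 1 to compound 3 (0.06 log units; that floor lies within the scatter), therefore offers only a floor, and it does not settle how 4-hydroxyphenyl and 2,6-dimethylphenyl compare at this place.

On these data alone, no step beyond the scatter has yet appeared at this position, so it remains open whether any group placed there can move the number clearly in either direction. A basic or acidic group, such as an amine or a carboxylic acid on the aromatic ring, or a longer chain such as 4-butylphenyl, would test this more sharply than another rearrangement of the same carbons, and the compounds shown give no hint of the outcome.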